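Methyl for methoxy on a chloro-bearing core: an expectation

This account rests on a few compounds, and the source may have more. Where it says the series, first, only, none or still open, it means among the compounds named here.

Measured compounds:
compound 1, `CCN(CC)CN1C(=O)/C(=N/NC(=S)Nc2ccc(OC)cc2)c2ccccc21`, 2400 nM
compound 2, `CCN(CC)CN1C(=O)/C(=N/NC(=S)Nc2ccc(C)cc2)c2ccccc21`, 29000 nM
compound 3, `CCN(CC)CN1C(=O)/C(=N/NC(=S)Nc2ccc(OC)cc2)c2cc(Cl)ccc21`, 11000 nM

In a functional assay on L1210 cells (Mus musculus) for inhibition, read by cell counting, with a stated time of 48 h (on this read-out higher numbers stand for weaker inhibition and lower numbers for stronger inhibition), compound 1 gives 2400 nM. Compound 2 differs from it by methyl in place of methoxy on an aromatic carbon and the step is a 12-fold higher number from compound 1 to compound 2 (1.08 log units; beyond the scatter). Compound 3 differs from compound 1 by chloro in place of hydrogen on an aromatic carbon, with a 4.6-fold higher number from compound 1 to compound 3 (0.66 log units; beyond the scatter). Compound 4, `CCN(CC)CN1C(=O)/C(=N/NC(=S)Nc2ccc(C)cc2)c2cc(Cl)ccc21`, is not yet measured; it differs from compound 3 by methyl in place of methoxy on an aromatic carbon, the same change seen from compound 1 to compound 2, here made on the core of compound 3. Within the data shown here, the step from compound 3 to compound 4 is expected to be a 7.3-fold higher number from compound 3 to compound 4 (0.86 log units; beyond the scatter), resting on the single earlier instance, a 12-fold higher number from compound 1 to compound 2 (1.08 log units; beyond the scatter); with one example only, a smaller or larger step is possible. Compound 4 is thus estimated at 80000 nM, between 25000 nM and 300000 nM.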

Compound 4, half-maximal inhibitory concentration: 9500 nM
Beside the measured number, compound 4's estimate is 8.4-fold (0.93 log units) above it, and the stated range ends above it.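

On the chloro-bearing core, methyl in place of methoxy gives a 1.2-fold lower number from compound 3 to compound 4 (0.06 log units; within the scatter) in this assay, so the large step seen on the core of compound 1 does not carry over to this core: the same change on two cores in this assay, a 12-fold higher number (1.08 log units; beyond the scatter) from compound 1 to compound 2 and a 1.2-fold lower number (0.06 log units; within the scatter) from compound 3 to compound 4, 14-fold (1.15 log units) apart, beyond the scatter of two such steps. Chloro in place of hydrogen likewise depends on its partner, giving a 3.1-fold lower number from compound 2 to compound 4 (0.48 log units; beyond the scatter), opposite in direction to its step on the methoxy compounds: the same change on two cores in this assay, a 4.6-fold higher number (0.66 log units; beyond the scatter) from compound 1 to compound 3 and a 3.1-fold lower number (0.48 log units; beyond the scatter) from compound 2 to compound 4, 14-fold (1.15 log units) apart, beyond the scatter of two such steps. Together these show that the two changes do not act independently in this pair of cores, but they do not show why, or how either change would behave on any other core.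

From the compounds shown here alone, it remains open whether a fluoro group or an ethoxy group on the aromatic ring would follow the methoxy or the methyl compounds. Going by these compounds, it is also open whether these steps would hold with a piperidine in place of the diethylamine.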